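Thione series in mice: chloro in place of fluoro

A few compounds are considered here, and "the series" means these few. Any claim that something is new, unique, unknown or untested is made for them only; others in the source may bear on it.

Measured so far in a functional assay on the whole organism with Mus musculus as the target; on this read-out higher numbers stand for an effect only at larger amounts of compound and lower numbers for an effect already at smaller amounts:
compound 1 `Cn1nc(-c2ccccc2)n(C)c1=O`: > 50 mg/kg
compound 2 `Cn1nc(-c2ccccc2F)n(C)c1=S`: 0.74 mg/kg
compound 3 `Cn1c(S)nnc1-c1ccccc1F`: > 25 mg/kg

In this assay, among the compounds with values here, compound 2 gives 0.74 mg/kg, the only actual number among the three results. For compound 1 the result is a limit only, > 50 mg/kg (the limit of > 50 mg/kg in this assay, at which 1 of the 3 values shown sits). For compound 3 the result is likewise a limit, > 25 mg/kg (the limit of > 25 mg/kg in this assay, at which 1 of the 3 values shown sits). Compound 4 `Cn1nc(-c2ccccc2Cl)n(C)c1=S` is not yet measured; it differs from compound 2 by chloro in place of fluoro on an aromatic carbon. Within the data shown here, no measured pair of this kind exists, so the size of this step is uncertain. With one heavy atom exchanged for one heavy atom, no ring and no change in donors, acceptors or charge, a step within the scatter of this assay is expected, a 1.1-fold higher number from compound 2 to compound 4 (0.03 log units; within the scatter). Compound 4 is therefore estimated at 0.8 mg/kg, between 0.3 mg/kg and 2.5 mg/kg.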

Compound 4, dose for half-maximal effect: 0.37 mg/kg
For compound 4 the middle estimate is 2.2-fold (0.33 log units) above the measured one; low and high end bracket the measured number.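

In this assay, within the data shown here, chloro in place of fluoro on an aromatic carbon, ortho to a group of 8 heavy atoms, gives a 2.0-fold lower number from compound 2 to compound 4 (0.30 log units; within the scatter) as the only measured pair of this kind. At this position, the two halogens therefore cannot be told apart in this series. Nothing available explains why the two compounds read alike.

As far as these compounds go, whether methoxy or an amine at this position would stay within the scatter of compound 2 remains open. A single pair also leaves open whether the same exchange behaves alike on other members of the series.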